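A Methyl on an Aromatic Oxygen, Measured Twice

The source may hold more compounds than are shown below. What is called first, only, known or untested is meant among the compounds shown, and "the series" means these compounds.

Three compounds were tested in a functional assay on A549 cells (Homo sapiens) for inhibition, read by MTT assay, with a stated time of 72 h; a lower number here means a stronger inhibitor, a higher number a weaker inhibitor. Compound 2 `COc1cc(O)cc(O)c1C(=O)/C=C/c1ccc(O)c(O)c1` gives 11800 nM. Compound 3 `COc1cc(OC)c(C(=O)/C=C/c2ccc(O)c(O)c2)c(OC)c1` gives 8200 nM, a figure within the scatter of that of compound 2; the difference between the two cores is not broken down here. Compound 1 `COc1cc(/C=C/C(=O)c2c(O)cc(O)cc2OC)ccc1O` reaches only a limit of this assay, > 50000 nM, and the limit of > 50000 nM in this assay, at which 1 of the 3 values shown sits, marks that limit. Between compound 2 and compound 1 the change is methyl in place of hydrogen on an oxygen on an aromatic ring, and it made an at least 4.2-fold higher number from compound 2 to compound 1 (0.62 log units; beyond the scatter).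

Compound 4 `COc1cc(OC)c(C(=O)/C=C/c2ccc(O)c(OC)c2)c(OC)c1` has not yet been measured. It differs from compound 3 by methyl in place of hydrogen on an oxygen on an aromatic ring, the same change as that from compound 2 to compound 1, made on the core of compound 3. Because compound 2 to compound 1 gave an at least 4.2-fold higher number from compound 2 to compound 1 (0.62 log units; beyond the scatter), a weakening of similar size is expected, so that the step is estimated as a 3.7-fold higher number from compound 3 to compound 4 (0.56 log units; beyond the scatter). Compound 4 is therefore expected to give about 30000 nM in this assay, with a plausible span from 10000 nM to 100000 nM, and a real chance that only a limit is reported.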

Compound 4, half-maximal inhibitory concentration: 43800 nM
Estimate against measurement, compound 4: 1.5-fold (0.16 log units) below; the measured number falls inside the stated range.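

In this assay, methyl in place of hydrogen on an oxygen on an aromatic ring again gives a weaker compound on the core of compound 3, with a 5.3-fold higher number from compound 3 to compound 4 (0.73 log units; beyond the scatter). Set beside the earlier step, the change goes in the same direction on both cores, and the comparison reads: the same change on two cores in this assay, an at least 4.2-fold higher number (0.62 log units; beyond the scatter) from compound 2 to compound 1 and a 5.3-fold higher number (0.73 log units; beyond the scatter) from compound 3 to compound 4; the limit leaves it open whether they differ. For compound 1 the value > 50000 nM is a limit of the assay and not a number, so the data show a shared direction but no shared size, and two cores make no rule for the rest of the series.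

The compounds shown leave open what happens when the oxygen carries something other than hydrogen or methyl, such as an ethyl group, a longer chain or an acetyl group. They also leave open whether an amine or a carboxylic acid in place of the hydroxy would give a number closer to that of compound 3 or to that of compound 4.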